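The compounds below may be only part of what the source reports. "The series", "measured", "known", "first", "only" and "open" are said of these compounds alone.

In a functional assay on cells (T-cell line, Homo sapiens) for inhibition (a higher number here means a weaker inhibitor, a lower number a stronger inhibitor), compound 1 `Clc1ccccc1CCCN1CCC(COC(c2ccccc2)c2ccccc2)CC1` gives 800 nM, while compound 2 `CCCN1CCC(COC(c2ccccc2)c2ccccc2)CC1` gives 17800 nM, the higher of the two numbers and so the weaker inhibitor. Compound 3 `CCCCCCN1CCC(COC(c2ccccc2)c2ccccc2)CC1` keeps the shared core but turns the propyl of compound 2 into hexyl: propyl in place of hydrogen on a saturated chain carbon, three bonds along the chain from an amine nitrogen in a ring. The change is propyl in place of hydrogen on a saturated chain carbon, three bonds along the chain from an amine nitrogen in a ring. Among the compounds with values here, one measured step bears on this same carbon: a 22-fold higher number from compound 1 to compound 2 (1.35 log units; beyond the scatter), a large rise when 2-chlorophenyl gives way to hydrogen. Read in reverse, that step suggests a group here can lower the number, but propyl is not 2-chlorophenyl, so only part of that size is expected. The expected move is a 5.1-fold lower number from compound 2 to compound 3 (0.71 log units; beyond the scatter), towards stronger inhibition and beyond the scatter. Compound 3 is estimated at 3500 nM, with an expected range of 1200 nM to 10000 nM.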

Compound 3, half-maximal inhibitory concentration: 5500 nM
The estimate for compound 3 lay 1.6-fold (0.20 log units) below the measured number; low and high end bracket the measured number.
By their numbers in this assay, from the lowest: compound 1; then compound 3; then compound 2.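

In this assay, a plain carbon group with no ring is enough to strengthen inhibition at this position: adding propyl on this saturated chain carbon gives a 3.2-fold lower number from compound 2 to compound 3 (0.51 log units; beyond the scatter). That gain is only partial, as replacing 2-chlorophenyl with propyl at the same carbon gives a 6.9-fold higher number from compound 1 to compound 3 (0.84 log units; beyond the scatter), so the group carrying the ring remains clearly the better of the two here. No supporting measurement is available to explain why either group changes the number as it does.

As far as these compounds go, it remains open whether a longer chain than hexyl would lower the number further or raise it again. A plain phenyl on this carbon, or an amine at the end of the chain, would help show whether the ring, the chlorine or something else matters most.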